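Formyl in Place of Bromo on the Pyridine Ring

The source may report more compounds than this note shows. Statements on the series, on what has been measured and on what is new or still open speak of the compounds shown alone.

Compound 3 `CC(C)c1ccc(NC(=O)N2CCN(c3ncccc3Br)CC2)cc1` stands lowest of the three compounds measured in a functional assay on HEK293 cells for antagonist activity at transient receptor potential cation channel subfamily V member 1 (Rattus norvegicus); on this read-out higher numbers stand for weaker inhibition and lower numbers for stronger inhibition; in that assay compound 3 gives 27.1 nM. Its nearest neighbour is compound 2 `CC(C)(C)c1ccc(NC(=O)N2CCN(c3ncccc3C(F)(F)F)CC2)cc1`, which in this assay gives 57.7 nM, and the furthest is compound 1 `Cc1ccc(NC(=O)N2CCN(c3ncccc3C(F)(F)F)CC2)cc1`, which gives 1550 nM. Among the measured compounds shown here, the only single-point step among the measured compounds is a 27-fold lower number from compound 1 to compound 2 (1.43 log units; beyond the scatter), and it concerns the phenyl-side group, not the pyridine ring.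

Compound 4 `CC(C)c1ccc(NC(=O)N2CCN(c3ncccc3C=O)CC2)cc1` differs from compound 3 in one place: formyl in place of bromo on an aromatic carbon. The site is an aromatic carbon of a six-membered aromatic ring with one nitrogen, ortho to a large group and two atoms from the ring nitrogen. For the measured compounds named here, no measured step bears on this site. Compounds 2 and 3 differ in two places at once, so their two values show only that both lie well below compound 1. With nothing measured to guide the direction, a step beyond the scatter in either direction cannot be excluded, and the expectation is a small weakening, a 1.8-fold higher number from compound 3 to compound 4 (0.27 log units; within the scatter). Compound 4 is therefore estimated at 50 nM, with a range from 15 nM to 200 nM.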

Compound 4, half-maximal inhibitory concentration: 1400 nM
Beside the measured number, compound 4's estimate is 28-fold (1.45 log units) below it; the whole stated range lies below it.
By their numbers in this assay, from the lowest: compound 3; then compound 2; then compounds 4 and 1 (each within the scatter of the next).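

In this assay, among the compounds shown here, the replacement of bromo by formyl on this aromatic carbon, ortho to a large group and two atoms from the ring nitrogen, gives a 52-fold higher number from compound 3 to compound 4 (1.71 log units; beyond the scatter), the first measured step at this site. The result shows that this position is far from indifferent to its substituent: with the rest of the molecule unchanged, a change from one heavy atom to two, bringing in a double bond and a hydrogen-bond acceptor, is enough for a large loss of inhibition. Nothing measured here explains why this step is so large.

The compounds shown leave open which feature of the formyl group matters, and a nitrile, a hydroxymethyl group, an amine or a chloro group at this site would help to separate the possibilities. They also leave open whether the step keeps its size with tert-butyl or methyl in place of the isopropyl group on the phenyl side, and how trifluoromethyl compares with bromo on this ring when the phenyl side is the same.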